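The source may report more compounds than this note shows. Statements on the series, on what has been measured and on what is new or still open speak of the compounds shown alone.

Of the compounds shown here, two of a shared core have been measured in a functional assay on CHO-K1 cells for agonist activity at Glucose-dependent insulinotropic receptor (Homo sapiens), read by a luciferase reporter, with a stated time of 5 h; on this read-out higher numbers stand for an effect only at larger amounts of compound and lower numbers for an effect already at smaller amounts. Compound 1 `CC(C)OC(=O)N1CCC(Oc2ncnc3c2CCN3c2ccc([S+]([O-])N(C)C)cc2)CC1` gives 501 nM. Compound 2 `CC(C)OC(=O)N1CCC(Oc2ncnc3c2CCN3c2ccc([S@@+](C)[O-])c(F)c2)CC1` gives 631 nM. The only step measured so far, a 1.3-fold higher number from compound 1 to compound 2 (0.10 log units; within the scatter), exchanges one group on the nitrogen on the aromatic ring in the ring for another; the two numbers sit within the scatter of each other, so compound 2 stands level with compound 1 on the numbers shown.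

Compound 3 `CC(C)OC(=O)N1CCC(Oc2ncnc3c2CCN3c2ccc([S@+](C)[O-])c(F)c2)CC1` is the mirror image of compound 2 at one point: the two compounds have the same atoms and bonds and differ only in configuration as drawn: 1 of 1 stereo elements differ; a stereocentre at a sulfur is drawn R in compound 2 and S in compound 3. Nothing else changes. For the measured compounds named here, no measured step bears directly on this: the step from compound 1 to compound 2 alters a whole group and says nothing about swapping the configuration at a sulfur. The two forms of such a sulfur can give quite different numbers in this assay, yet no direction is known from these data. For compound 3 the estimate therefore sits near compound 2, with a wide range on both sides: 630 nM, between 150 nM and 2500 nM, which means an expected step of a 1.0-fold lower number from compound 2 to compound 3 (0.00 log units; within the scatter).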

Compound 3, half-maximal effective concentration: 50.1 nM
The estimate for compound 3 lay 13-fold (1.10 log units) above the measured number; measured number outside the range, below it.
By their numbers in this assay, from the lowest: compound 3; then compounds 1 and 2 (each within the scatter of the next).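

In this assay, the configuration at the sulfur is far from a minor detail, since reversing it alone gives a 13-fold lower number from compound 2 to compound 3 (1.10 log units; beyond the scatter). That gap can be laid on this single stereocentre because nothing else separates the pair: the fact that compounds 2 and 3 differ only in the configuration as drawn. The earlier comparison had hidden this: a 1.3-fold higher number from compound 1 to compound 2 (0.10 log units; within the scatter), whereas the form drawn S stands clearly apart from compound 1, with a 10-fold lower number from compound 1 to compound 3 (1.00 log units; beyond the scatter), so whether a change of group at this sulfur appears to matter depends on which sulfur configuration is compared.

The step to compound 3 still changes the dimethylamino group to methyl and adds a fluorine at the same time, and compound 1 has no configuration drawn at its sulfur, so neither the share of each change nor the effect of configuration in compound 1 can be read. On these data alone, it also remains open whether the same preference for the form drawn S would hold with a larger group on the sulfur, such as an ethyl in place of the methyl.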